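A few compounds are considered here, and "the series" means these few. Any claim that something is new, unique, unknown or untested is made for them only; others in the source may bear on it.

Measured so far:
compound 1, `CNCCCNc1c(F)cc2c(=O)c(C(=O)O)cn(Cc3ccc(-c4ccccc4)cc3)c2c1OC`: in an assay on isolated protein for inhibition of DNA topoisomerase 1 (Homo sapiens), with a stated time of 15 min (a lower number here means a stronger inhibitor, a higher number a weaker inhibitor), compound 1 gives 101000 nM
compound 2, `CN[C@@H]1CCN(c2cc3c(cc2F)c(=O)c(C(=O)O)cn3Cc2ccc(-c3ccccc3)cc2)C1`: in this assay compound 2 gives 34800 nM
compound 3, `COc1c(N2CC[C@@H](CN)C2)c(F)cc2c(=O)c(C(=O)O)cn(Cc3ccc(-n4cccn4)cc3)c12`: in this assay compound 3 gives > 200000 nM

The value for compound 3 is a limit of this assay and not a number, as marked by the limit of > 200000 nM in this assay, at which 1 of the 3 values shown sits. Compounds 1 and 2 give numbers, and both sit far toward the weak end of the scale. Among the compounds with values here, no two of the three measured compounds differ in a single place, so no measured step is counted within the set; only the values themselves can be compared, and compound 2 gives the stronger number of the two that have one.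

Compound 4, `COc1c(N2CC[C@@H](CN)C2)c(F)cc2c(=O)c(C(=O)O)cn(Cc3cc(-c4ccccc4)no3)c12`, has not been measured. It differs from compound 3 in one place: 3-phenyl-1,2-oxazol-5-yl in place of 4-(1H-pyrazol-1-yl)phenyl on a saturated chain carbon bound to an aromatic nitrogen. The group that leaves and the group that enters are of the same size and carry the same count of acceptors and donors, and the rest of the structure is unchanged.

With compound 3 standing only at a limit, the expected step of an at least 1.3-fold lower number from compound 3 to compound 4 (0.12 log units; that floor lies within the scatter) is small, direction uncertain, and there is a fair chance that compound 4 again returns only a limit. Compound 4 is estimated at 150000 nM in this assay, within 40000 nM to 500000 nM.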

Compound 4, half-maximal inhibitory concentration: 178000 nM
For compound 4 the middle estimate is 1.2-fold (0.07 log units) below the measured one, and the stated range covers the measured number.
By their numbers in this assay, from the lowest: compound 2; then compounds 1 and 4 (each within the scatter of the next). At a limit, above all of these: compound 3.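

In this assay, placing 3-phenyl-1,2-oxazol-5-yl in place of 4-(1H-pyrazol-1-yl)phenyl on a saturated chain carbon bound to an aromatic nitrogen gives an at least 1.1-fold lower number from compound 3 to compound 4 (0.05 log units; that floor lies within the scatter). Within the data shown here, this is the first single-place step in the set, and it shows that this exchange of two groups with the same heavy-atom count and the same acceptor and donor counts leaves the series at the weak end of the scale, with compound 4 at 178000 nM. The step can be stated only as a floor and not as a size, because the value of compound 3 is a limit of the assay and not a number: the limit of > 200000 nM in this assay, at which 1 of the 4 values shown sits.

As far as these compounds go, the true size of the step from the pyrazolyl-bearing group to the oxazolyl-bearing group remains unknown, and it is still open whether any other group at this place, such as a plain benzyl or a benzyl carrying a carboxylic acid, would move the number beyond the scatter. Among these compounds, no single-place step links compound 1 or compound 2 to compound 3 or compound 4, so the part played by the amine side chain and the methoxy group stays unresolved.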